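A few compounds are considered here, and "the series" means these few. Any claim that something is new, unique, unknown or untested is made for them only; others in the source may bear on it.

Measured so far:
Compound 1 `COc1cc2c(Oc3ccc(NC(=O)c4nccc(-c5ccc(C)cc5)n4)cc3F)ccnc2cc1OCCCN1CCN(C)CC1`, in a functional assay on NCI-H460 cells (Homo sapiens) for cytotoxicity, read by MTT assay, with a stated time of 72 h (on this read-out lower numbers stand for stronger inhibition and higher numbers for weaker inhibition), compound 1 gives 160 nM.
Compound 2 `COc1cc2c(Oc3ccc(NC(=O)c4nccc(-c5ccc(F)cc5)n4)cc3F)ccnc2cc1OCCCN1CCN(C)CC1`, in this assay compound 2 gives 63 nM.

Within the data shown here, compound 1 holds the higher of these two numbers; its only neighbour is compound 2, reached by a 2.5-fold lower number from compound 1 to compound 2 (0.40 log units; beyond the scatter), a change on the aromatic ring far from the chain. Compound 3 `COc1cc2c(Oc3ccc(NC(=O)c4nccc(-c5ccc(C)cc5)n4)cc3F)ccnc2cc1OCCCN1CCCC1` differs from compound 1 by pyrrolidin-1-yl in place of 4-methylpiperazin-1-yl on a saturated chain carbon, three bonds along the chain from an oxygen on an aromatic ring. Among the measured compounds shown here, no measured step touches this chain end, so the single step seen gives no guide to direction or size here. The step is therefore expected to be no change at the digits printed from compound 1 to compound 3 (within the scatter), not beyond the scatter. Compound 3 is estimated at 160 nM, with a range from 60 nM to 450 nM.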

Compound 3, half-maximal inhibitory concentration: 440 nM
For compound 3 the middle estimate is 2.8-fold (0.44 log units) below the measured one, and the stated range covers the measured number.
By their numbers in this assay, from the lowest: compound 2; then compound 1; then compound 3.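

In this assay, the chain end proves to be a position that responds: pyrrolidin-1-yl in place of 4-methylpiperazin-1-yl gives a 2.8-fold higher number from compound 1 to compound 3 (0.44 log units; beyond the scatter). Of the two chain ends measured, 4-methylpiperazin-1-yl therefore goes with the lower number, at least with methyl on the aromatic ring. Nothing available explains this step.

On these data alone, whether a morpholine or a dimethylamino group at the chain end would fall nearer compound 1 or compound 3 remains open. So does whether the same step holds with the fluoro group of compound 2.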